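The source may report more compounds than this note shows. Statements on the series, on what has been measured and on what is new or still open speak of the compounds shown alone.

Within the data shown here, compound 1 `CC(=O)c1cccc(Nc2ccnc(SCC(=O)c3ccc(-c4ccccc4)cc3)n2)c1` is the lower of the two compounds measured so far: in a functional assay on SF-539 cells (Homo sapiens) for inhibition, read by sulforhodamine B assay, with a stated time of 48 h, tested at 10 uM (on this read-out lower numbers stand for less inhibition of growth and higher numbers for more inhibition of growth at the one concentration tested), compound 1 gives 11%. Its nearest neighbour, compound 2 `COc1ccc(C(=O)CSc2nccc(Nc3cccc(C(C)=O)c3)n2)cc1`, gives 12% in this assay, and the step of a number 1 percentage points higher from compound 1 to compound 2 (within the scatter) lies within the scatter. Compound 3 `CC(=O)c1ccc(Nc2ccnc(SCC(=O)c3ccc(-c4ccccc4)cc3)n2)cc1` carries a different change: 4-acetylphenyl in place of 3-acetylphenyl on a nitrogen on an aromatic ring. Among the measured compounds shown here, no measured step touches this position, so the only guide is the flat series itself, with both numbers low. The expected step of a number 1 percentage points higher from compound 1 to compound 3 (within the scatter) is none beyond the scatter. For compound 3 the estimate in this assay is 12%, range 0% to 28%.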

Compound 3, percent growth inhibition at one concentration: 13%
The estimate for compound 3 lay 1 percentage points below the measured number; low and high end bracket the measured number.
By their numbers in this assay, from the lowest: compounds 1, 2 and 3 (each within the scatter of the next).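

Among these compounds, this is the first read on the position of the acetyl group on this ring. In this assay, 4-acetylphenyl in place of 3-acetylphenyl on a nitrogen on an aromatic ring gives a number 2 percentage points higher from compound 1 to compound 3 (within the scatter) and so does not separate the two compounds at the one concentration tested. No independent data bear on this result.

From the compounds shown here alone, whether a carboxylic acid or an amine in place of the acetyl group would move the number out of this low range stays open. The same holds for a longer chain at this position.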